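The source may hold more compounds than are shown below. What is called first, only, known or untested is meant among the compounds shown, and "the series" means these compounds.

Measured so far in an in vitro ADME assay on microsomes from liver (Homo sapiens) for metabolic stability, read by LC-MS, tested at 1 uM; on this read-out higher numbers stand for fast clearance and lower numbers for slow clearance:
- compound 1 `CN(C)S(=O)(=O)c1ccc(F)c(C#Cc2cc(Cl)ccc2OCC(=O)O)c1`: < 10 mL.min-1.g-1 (a limit)
- compound 2 `CCCS(=O)(=O)c1ccc(F)c(C#Cc2cc(Cl)ccc2OCC(=O)O)c1`: 12 mL.min-1.g-1
- compound 3 `Cc1ccc(S(=O)(=O)N(C)C(C)C)cc1C#Cc1cc(Cl)ccc1OCC(=O)O`: < 10 mL.min-1.g-1 (a limit)

Compound 3 gives only a limit, < 10 mL.min-1.g-1. That is the limit of < 10 mL.min-1.g-1 in this assay, at which 2 of the 3 values shown sit.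

Compound 4 `Cc1ccc(S(=O)(=O)NC(C)C)cc1C#Cc1cc(Cl)ccc1OCC(=O)O` comes from compound 3 by hydrogen in place of methyl on a sulfonamide nitrogen. Among the measured compounds shown here, the one measured step, an at least 1.2-fold higher number from compound 1 to compound 2 (0.07 log units; that floor lies within the scatter), is a different change, propyl in place of dimethylamino on a sulfonyl sulfur, so it bears only loosely on this one. For the measured compounds named here, no measured step covers this change directly. No step beyond the scatter is therefore expected in this assay, and no direction can be given. The estimate amounts to an expected a number no lower from compound 3 to compound 4 (the limit leaves the size open). Compound 4 is expected at 10 mL.min-1.g-1, with an estimated range of 5 mL.min-1.g-1 to 20 mL.min-1.g-1.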

Compound 4, intrinsic clearance in microsomes: < 10 mL.min-1.g-1
Compound 4 ended at the assay's limit (the forecaster's own chance of this, stated with the estimate: 65%); the middle value sits exactly at the limit.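

No step can be read between compound 3 and compound 4 in this assay, and both values are limits: the limit of < 10 mL.min-1.g-1 in this assay, at which 3 of the 4 values shown sit.

The compounds shown leave open whether hydrogen in place of methyl on a sulfonamide nitrogen changes clearance at all.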